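The source may report more compounds than this note shows. Statements on the series, on what has been measured and on what is new or still open speak of the compounds shown alone.

In a functional assay (Homo sapiens) for inhibition, with a stated time of 72 h (a lower number here means a stronger inhibitor, a higher number a weaker inhibitor), compound 3 `CCn1ccc2cc(C(=O)c3cc(OC)c(OC)c(OC)c3)ccc21` gives 40 nM, and compound 2 `COc1cc(C(=O)c2cccc3[nH]ccc23)cc(OC)c1OC` gives 51.4 nM. These two values lie within the scatter of each other, so compound 3 stands level with compound 2. Compound 1 `COc1cc(C(=O)n2ccc3ccccc32)cc(OC)c1OC` is reported only as a limit, > 10000 nM.

The next compound, compound 4 `COc1cc(C(=O)c2ccc3c(ccn3CCN(C)C)c2)cc(OC)c1OC`, is built on compound 3 with a single change, (dimethylamino in place of hydrogen on a saturated chain carbon, two bonds along the chain from an aromatic nitrogen). Dimethylamino takes the place of hydrogen on a saturated chain carbon, two bonds along the chain from an aromatic nitrogen, so that ethyl becomes 2-(dimethylamino)ethyl. No measured pair among these compounds shows what this change does, which leaves the expectation resting on the value of compound 3 at 40 nM and carrying a wide margin. A moderate weakening is expected rather than a collapse in this assay, and the expected step is a 3.0-fold higher number from compound 3 to compound 4 (0.48 log units; beyond the scatter). For compound 4 the estimated value is 120 nM, with an expected range from 30 nM to 500 nM.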

Compound 4, half-maximal inhibitory concentration: 4900 nM
Compound 4: the middle estimate sits 41-fold (1.61 log units) below what was measured, outside the stated range (above it).
By their numbers in this assay, from the lowest: compounds 3 and 2 (each within the scatter of the next); then compound 4. At a limit, above all of these: compound 1.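

In this assay, dimethylamino in place of hydrogen on the saturated chain carbon, two bonds along the chain from an aromatic nitrogen, gives a large weakening: a 120-fold higher number from compound 3 to compound 4 (2.09 log units; beyond the scatter). Among these compounds, this is the first sign that this chain does not take such a group freely, although the change still leaves a measured number rather than a limit. Compound 1 alone stands at a limit: the limit of > 10000 nM in this assay, at which 1 of the 4 values shown sits.

From the compounds shown here alone, whether the loss comes from the amine itself or from the longer chain stays open, and a plain butyl chain or a 2-methoxyethyl chain in the same place would separate the two. Also open, going by these compounds, is whether a primary amine, a morpholine or a carboxylic acid at the end of the chain would fare the same way.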